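Ethyl to isopropyl in a weakly active antiproliferative series

The source may hold more compounds than are shown below. What is called first, only, known or untested is meant among the compounds shown, and "the series" means these compounds.

Measured compounds:
compound 1, `CC(C)n1c(/C=C2\SC(=O)N(CC(=O)N3CCOCC3)C2=O)nc2ccccc21`: > 50000 nM
compound 2, `CCn1c(/C=C2\SC(=O)N(CC(=O)N3CCc4cc(OC)c(OC)cc4C3)C2=O)nc2ccccc21`: 33500 nM
compound 3, `CCn1c(/C=C2\SC(=O)N(CC(=O)N3CCOCC3)C2=O)nc2ccccc21`: > 50000 nM

All three were run in a functional assay on PC-3 cells (Homo sapiens) for inhibition, read by MTT assay, with a stated time of 48 h; on this read-out higher numbers stand for weaker inhibition and lower numbers for stronger inhibition. Compound 2 is the only one of them with a number: in this assay compound 2 gives 33500 nM. For compound 1 the result in this assay is a limit of the assay, > 50000 nM. For compound 3 the result in this assay is likewise a limit, > 50000 nM. The change from compound 3 to compound 1, (methyl in place of hydrogen on a saturated chain carbon bound to an aromatic nitrogen and a saturated chain carbon), therefore gives a step whose size is not readable, a step that the two limits leave unreadable from compound 3 to compound 1, because of the limit of > 50000 nM in this assay, at which 2 of the 3 values shown sit. Compound 2 and compound 3 differ in a larger part of the molecule; the difference between the two cores is not broken down here.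

Compound 4, `COc1cc2c(cc1OC)CN(C(=O)CN1C(=O)S/C(=C\c3nc4ccccc4n3C(C)C)C1=O)CC2`, is not yet measured. It stands to compound 2 as compound 1 stands to compound 3: methyl in place of hydrogen on a saturated chain carbon bound to an aromatic nitrogen and a saturated chain carbon, the same change at the same place. Within the data shown here, the only earlier instance gives no readable size, so the step from compound 2 to compound 4 is expected to be small, a 1.2-fold higher number from compound 2 to compound 4 (0.08 log units; within the scatter), and this expectation rests on nothing more than the unread step that the two limits leave unreadable from compound 3 to compound 1 and the single number of compound 2, 33500 nM. With compound 2 already close to the limit of the assay, compound 4 may well return only a limit again. Compound 4 is expected to give about 40000 nM in this assay, with a range from 12000 nM to 120000 nM.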

Compound 4, half-maximal inhibitory concentration: > 50000 nM
Compound 4 gave a limit, no number; the forecaster's own chance of this, stated with the estimate: 40%; middle value at least 1.2-fold (0.09 log units) away from the limit.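

On the core of compound 2, ethyl to isopropyl gives, in this assay, an at least 1.4-fold higher number from compound 2 to compound 4 (0.17 log units; that floor lies within the scatter); this is a floor and not a measured size, and the true step could be small or considerably larger. Among these compounds, on the core of compound 3 the same change cannot be read, so the two cores offer no pair of sizes to compare, and nothing shows that the change has the same effect on both or that its size carries from one core to the other. The result shows only that compound 4, like compound 1, ends at a limit of the assay, and the series can say no more about this change because most of its results end there: the limit of > 50000 nM in this assay, at which 3 of the 4 values shown sit.

Still open, on these data alone, is how other groups on the aromatic nitrogen would read in place of ethyl or isopropyl, for example a hydrogen, a cyclopropyl or a benzyl group. Also open is whether an amide part other than the two shown, such as a piperidine or one carrying a carboxylic acid, would give a core with numbers far enough from the limit for the ethyl to isopropyl step to be sized.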